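The source may report more compounds than this note shows. Statements on the series, on what has been measured and on what is new or still open speak of the compounds shown alone.

Measured in a functional assay on NCI/ADR cells (Homo sapiens) for cytotoxicity, read by sulforhodamine B assay; a lower number here means a stronger inhibitor of growth, a higher number a weaker inhibitor of growth:
- Compound 1 `CC1=CC[C@@H]([C@@](C)(O)CCCC(C)(C)NC(=S)NN)CC1`: 29000 nM
- Compound 2 `CC1=CC[C@@H]([C@@](C)(O)CCCC(C)(C)NC(=S)N/N=C\c2ccc(N(C)C)cc2)CC1`: > 100000 nM (a limit)
- Compound 3 `CC1=CC[C@@H]([C@@](C)(O)CCCC(C)(C)NC(=S)N/N=C\c2ccccc2[N+](=O)[O-])CC1`: > 100000 nM (a limit)

Only compound 1 has a true number, at 29000 nM. Compound 3 gives > 100000 nM, which is a limit of the assay and not a number. Its exact place on the scale is therefore unknown. Compound 2 shares that position, and together they make up (the limit of > 100000 nM in this assay, at which 2 of the 3 values shown sit).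

Compound 4 `CC1=CC[C@@H]([C@@](C)(O)CCCC(C)(C)NC(=S)N/N=C\c2cccc(Cl)c2)CC1` carries 3-chlorophenyl in place of 2-nitrophenyl on a carbon with a double bond to nitrogen.

Going by the values given here, only one measured step bears on this place, a step that the two limits leave unreadable from compound 2 to compound 3. It offers no size to carry over, so any expectation rests on the two limits themselves. With both compounds that carry a substituted phenyl at this place lying at the limit of > 100000 nM in this assay, at which 2 of the 3 values shown sit, compound 4 is expected to stay at or close to that limit. If it does give a number, the only direction open from compound 3 is toward stronger growth inhibition in this assay.

The expected step is an at least 1.2-fold lower number from compound 3 to compound 4 (0.09 log units; that floor lies within the scatter). For compound 4 the estimated value is 80000 nM, with an expected range from 30000 nM to 200000 nM.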

Compound 4, concentration for total growth inhibition: 31900 nM
The estimate for compound 4 lay 2.5-fold (0.40 log units) above the measured number; measured number inside the range.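

In this assay, the place on a carbon with a double bond to nitrogen turns out to accept a substituted phenyl and still give a true number: 3-chlorophenyl in place of 2-nitrophenyl gives an at least 3.1-fold lower number from compound 3 to compound 4 (0.49 log units; beyond the scatter), and 3-chlorophenyl in place of 4-(dimethylamino)phenyl gives an at least 3.1-fold lower number from compound 2 to compound 4 (0.49 log units; beyond the scatter). Compound 2 and compound 3 therefore no longer speak for every substituted phenyl here, and each of them holds only a limit of the assay, not a number: the limit of > 100000 nM in this assay, at which 2 of the 4 values shown sit. Compound 4 still does not separate from compound 1, with the larger group in place of one nitrogen atom giving a 1.1-fold higher number from compound 1 to compound 4 (0.04 log units; within the scatter), so 3-chlorophenyl clears the limit without adding measurable growth inhibition over the compound that lacks it.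

The compounds shown do not separate the effect of the chlorine from that of its place on the ring, as 2-nitrophenyl, 4-(dimethylamino)phenyl and 3-chlorophenyl differ in both at once. On these data alone, whether a plain phenyl, a methoxy group or a pyridine ring at this place would give a number, and whether any of them would go clearly beyond compound 1, stays open.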